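Butylsulfanyl in Place of Allyloxy: What Cytotoxicity to Expect

The compounds below may be only part of what the source reports. "The series", "measured", "known", "first", "only" and "open" are said of these compounds alone.

Three compounds were measured in an ADME assay on Akata cells (Homo sapiens) for cytotoxicity, with a stated time of 7 days (a higher number here means that more compound is tolerated, a lower number that less compound is tolerated), and each gave only a limit of the assay rather than a number.

Compound 1, `C=CCOc1nc(N)nc2c1ncn2/C=C1/CC1(CO)CO`, > 20000 nM.
Compound 2, `CCCSc1nc(N)nc2c1ncn2/C=C1/CC1(CO)CO`, > 20000 nM.
Compound 3, `Nc1nc(NC2CCCC2)c2ncn(/C=C3/CC3(CO)CO)c2n1`, > 20000 nM.

Compound 1 thus stands at the limit, and the same is true of every measured value, as the evidence shows: the limit of > 20000 nM in this assay, at which 3 of the 3 values shown sit. The compound to be judged is compound 4, `CCCCSc1nc(N)nc2c1ncn2/C=C1/CC1(CO)CO`. Its difference from compound 1 is butylsulfanyl in place of allyloxy on an aromatic carbon.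

The measured steps that bear on this change are the ones that swap the same allyloxy group for another group on the same aromatic carbon: a step that the two limits leave unreadable from compound 1 to compound 2 and a step that the two limits leave unreadable from compound 1 to compound 3. A third step, a step that the two limits leave unreadable from compound 2 to compound 3, is unreadable as well. None of these steps gives a size. Both ends of each of them sit at the limit. So no direction and no size beyond the scatter can be read for the step to compound 4 either.

For compound 4 the expectation is that this assay will again report only a limit, and the estimate is 30000 nM, between 15000 nM and 100000 nM. The step this estimate means, a step that the limit leaves unreadable from compound 1 to compound 4, is expected to remain unreadable.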

Compound 4, half-maximal cytotoxic concentration: > 20000 nM
Compound 4: only a limit was reported; the forecaster's own chance of this, stated with the estimate: 90%; the middle value is on the limit's open side.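

Compound 4 also gave only a limit in this assay, so none of the steps joining it to compound 1, compound 2 and compound 3 can be read: the limit of > 20000 nM in this assay, at which 4 of the 4 values shown sit.

The compounds shown leave open whether allyloxy, propylsulfanyl, butylsulfanyl and cyclopentylamino on this aromatic carbon differ at all in this assay, and at what concentration any of these compounds becomes cytotoxic.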